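The source may hold more compounds than are shown below. What is called first, only, known or untested is meant among the compounds shown, and "the series" means these compounds.

Measured compounds:
- compound 1 `Cc1cc(=O)oc2cc(OCc3cn(-c4cccc(F)c4)nn3)ccc12` in an ADME assay on Huh-7 cells (Homo sapiens) for cytotoxicity, read by MTT assay, with a stated time of 72 h; on this read-out higher numbers stand for lower toxicity in this test and lower numbers for higher toxicity in this test: > 100 ug/mL
- compound 2 `Cc1cc(C)cc(-n2cc(COc3ccc4c(C)cc(=O)oc4c3)nn2)c1` in this assay: > 100 ug/mL
- compound 3 `COC(=O)Cn1cc(COc2ccc3c(C)cc(=O)oc3c2)nn1` in this assay: > 100 ug/mL

All three compounds share the same core and differ only in the group carried on an aromatic nitrogen. For compound 1 the result in this assay is a limit of the assay rather than a number. The same holds for compound 2, whose result is a limit. Compound 3 likewise ends at a limit. The steps among them therefore cannot be sized: a step that the two limits leave unreadable from compound 1 to compound 2, a step that the two limits leave unreadable from compound 1 to compound 3 and a step that the two limits leave unreadable from compound 2 to compound 3 remain unreadable because of the limit of > 100 ug/mL in this assay, at which 3 of the 3 values shown sit.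

Compound 4 `Cc1cc(=O)oc2cc(OCc3cn(Cc4ccccc4)nn3)ccc12` is not yet measured. It differs from compound 3 in one place: phenyl in place of methoxycarbonyl on a saturated chain carbon bound to an aromatic nitrogen. Within the data shown here, none of the measured steps gives a readable size, so there is no basis for expecting a change beyond the scatter; the three measured compounds, whatever their substituent on the aromatic nitrogen, all sit at the same limit. For compound 4 the step is expected to be a number no higher from compound 3 to compound 4 (the limit leaves the size open), that is, no shift that can be seen. Compound 4 is thus estimated at 100 ug/mL, with a range from 50 ug/mL to 200 ug/mL, and most likely the assay will again report only a limit.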

Compound 4, half-maximal cytotoxic concentration: > 100 ug/mL
Compound 4 gave a limit, no number; the forecaster's own chance of this, stated with the estimate: 80%; the middle value lies on the limit itself.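

In this assay compound 4 gives > 100 ug/mL, which is a limit and not a number. Its steps from compound 1, compound 2 and compound 3 therefore cannot be read: the limit of > 100 ug/mL in this assay, at which 4 of the 4 values shown sit. The compounds shown leave open what actual value any of them would reach in this assay, and whether changing the group on the aromatic nitrogen alters that value at all.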